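This account rests on a few compounds, and the source may have more. Where it says the series, first, only, none or still open, it means among the compounds named here.

Measured in a functional assay on HepG2 cells (Homo sapiens) for inhibition, read by MTT assay, with a stated time of 72 h; on this read-out lower numbers stand for stronger inhibition and higher numbers for weaker inhibition:
- compound 1 `COc1cc(OC)c(C(=O)/C=C/c2ccccc2OC)c(OC)c1`: 16300 nM
- compound 2 `COc1cc(OC)c(C(=O)/C=C/c2ccccc2[N+](=O)[O-])c(OC)c1`: 7900 nM

Compound 1 has the higher of these two numbers, which makes it the weaker inhibitor of the pair. Compound 3 `COc1cc(OC)c(C(=O)/C=C/c2ccc(N)cc2)c(OC)c1` has not yet been measured. It keeps the core of compound 1 and changes one group: 4-aminophenyl in place of 2-methoxyphenyl on a double-bonded chain carbon bound to a double-bonded chain carbon. For the measured compounds named here, only one measured step bears on this change, since it also removes the methoxy of that 2-methoxyphenyl group: a 2.1-fold lower number from compound 1 to compound 2 (0.31 log units; beyond the scatter). That step is modest. A single step with nitro entering says little about an amino group entering, so this expectation is tentative. Still, the step seen with compound 2 suggests a similarly modest move towards a lower number in this assay. The expected change is a 2.0-fold lower number from compound 1 to compound 3 (0.31 log units; beyond the scatter). For compound 3 the estimate is 8000 nM, with an expected range of 2500 nM to 25000 nM.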

Compound 3, half-maximal inhibitory concentration: 45200 nM
Estimate against measurement, compound 3: 5.7-fold (0.75 log units) below; measured number above the stated range.
By their numbers in this assay, from the lowest: compound 2; then compound 1; then compound 3.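

In this assay the replacement of 2-methoxyphenyl at this place does not always push the number the same way: 4-aminophenyl gives a 2.8-fold higher number from compound 1 to compound 3 (0.44 log units; beyond the scatter) while the earlier nitro change gave a 2.1-fold lower number from compound 1 to compound 2 (0.31 log units; beyond the scatter) in the opposite direction. The number at this double-bonded chain carbon can therefore fall or rise with the group it carries, although both moves are modest. Nothing measured here gives a cause for the rise.

Compound 1 and compound 3 differ both in the substituent on the phenyl ring and in its numbered place there, so the compounds shown cannot separate these two changes. On these data alone, whether a hydroxyl group, a carboxylic acid or an acetamide on that ring would behave more like the amino group or the nitro group also remains open.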